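The source may report more compounds than this note shows. Statements on the series, on what has been measured and on what is new or still open speak of the compounds shown alone.

In a functional assay on HeLa cells (Homo sapiens) for inhibition, read by MTT assay, with a stated time of 72 h (a lower number here means a stronger inhibitor, a higher number a weaker inhibitor), compound 1 `Cc1ccc(-c2nnc(SCCCN3CCN(c4nc5ccccc5o4)CC3)o2)cc1` gives 133000 nM and compound 2 `Clc1ccc(-c2nnc(SCCCN3CCN(c4nc5ccccc5o4)CC3)o2)cc1` gives 101000 nM. These two numbers lie within the usual scatter of repeated measurements, so the data do not separate compound 2 from compound 1, and neither can be called the better inhibitor.

Compound 3 `Brc1ccc(-c2nnc(SCCCN3CCN(c4nc5ccccc5o4)CC3)o2)cc1` differs from compound 2 in one place: bromo in place of chloro on an aromatic carbon. This puts bromo in place of chloro on an aromatic carbon, para to a large group, turning 4-chlorophenyl into 4-bromophenyl.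

Going by the values given here, only one measured step bears on this change: a 1.3-fold lower number from compound 1 to compound 2 (0.12 log units; within the scatter), which puts chloro in place of methyl on the same aromatic carbon and stays within the scatter. Among the compounds with values here, a single step is thin evidence, and no bromo compound has been measured yet. On this evidence, no change beyond the scatter is expected in this assay, and no direction can be argued. The expected step is a 1.0-fold lower number from compound 2 to compound 3 (0.00 log units; within the scatter). The estimate for compound 3 is 100000 nM, with an expected range from 50000 nM to 190000 nM.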

Compound 3, half-maximal inhibitory concentration: 187000 nM
The estimate for compound 3 lay 1.9-fold (0.27 log units) below the measured number, within the range that was stated.
By their numbers in this assay, from the lowest: compounds 2, 1 and 3 (each within the scatter of the next).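

In this assay, putting bromo in place of chloro, which turns 4-chlorophenyl into 4-bromophenyl, gives a 1.9-fold higher number from compound 2 to compound 3 (0.27 log units; within the scatter), and putting bromo in place of methyl on the same aromatic carbon gives a 1.4-fold higher number from compound 1 to compound 3 (0.15 log units; within the scatter). Both steps lie within the scatter, as did the earlier step from methyl to chloro, so all three pairs among these groups have now been read at this position and none of them separates: methyl, chloro and bromo cannot be put in any order here, and the change from one halogen to a larger one adds no measurable difference. No measured property of these compounds is available to account for this result.

From the compounds shown here alone, whether a group of a different kind on this aromatic carbon, such as an amine, a carboxylic acid or a nitrile, would move the number beyond the scatter remains open. Also open, going by these compounds, is whether changes elsewhere in the shared core, such as a longer chain in place of the present one, would separate compounds in a way these three swaps do not.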